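This account rests on a few compounds, and the source may have more. Where it says the series, first, only, none or still open, it means among the compounds named here.

Measured so far:
compound 1 `CCCCOC(=O)c1ccc(COC(COCc2ccc(OC)cc2)Cn2ccnc2)cc1` — 200 nM
compound 2 `COc1ccc(COCC(Cn2ccnc2)OCc2ccc(C(=O)OCc3ccccc3)cc2)cc1` — 1490 nM
compound 3 `CCOC(=O)c1cccc(COC(COCc2ccc(OC)cc2)Cn2ccnc2)c1` — 7200 nM

In a functional assay for inhibition of Thromboxane-A synthase (Homo sapiens) (on this read-out lower numbers stand for stronger inhibition and higher numbers for weaker inhibition), compound 1 gives the lowest of the three numbers, with compound 2 nearest and compound 3 furthest, both beyond the scatter. Going by the values given here, the one single-site step measured, a 7.5-fold higher number from compound 1 to compound 2 (0.87 log units; beyond the scatter), touches the ester at the same end of the molecule. Compound 3 differs from compound 1 in more than one place, so its value shows only that the ester region is sensitive to change.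

Compound 4 `COc1ccc(COCC(Cn2ccnc2)OCc2ccc(C(=O)N(C)C)cc2)cc1` differs from compound 1 by dimethylamino in place of butoxy on a carbonyl carbon. This alters the same ester that weakened compound 2, and goes further by replacing the ester oxygen entirely, so weaker inhibition than compound 1 is expected: a 7.5-fold higher number from compound 1 to compound 4 (0.88 log units; beyond the scatter). Compound 4 is estimated at 1500 nM, within 300 nM to 8000 nM.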

Compound 4, half-maximal inhibitory concentration: 1940 nM
Beside the measured number, compound 4's estimate is 1.3-fold (0.11 log units) below it, and the stated range covers the measured number.
By their numbers in this assay, from the lowest: compound 1; then compounds 2 and 4 (each within the scatter of the next); then compound 3.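

In this assay, dimethylamino in place of butoxy on the carbonyl carbon gives a 9.7-fold higher number from compound 1 to compound 4 (0.99 log units; beyond the scatter), so the loss seen with benzyloxy also appears with a group that is not an ester. Dimethylamino in place of benzyloxy gives a 1.3-fold higher number from compound 2 to compound 4 (0.11 log units; within the scatter), so these two groups cannot be told apart here, and among the three groups at this place only butoxy gives the lower number. Nothing available explains why butoxy stands apart. Still open, from the compounds shown here alone, is how a carboxylic acid or a longer chain such as hexyloxy on this carbonyl carbon would compare with butoxy.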